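Where a new ring group may take solubility

This account rests on a few compounds, and the source may have more. Where it says the series, first, only, none or still open, it means among the compounds named here.

In a physicochemical assay for solubility, read by LC-MS, in phosphate buffer, with a stated time of 24 h, at pH 7.4 (a higher number here means a more soluble compound, a lower number a less soluble compound), compound 2 `CN(c1ncco1)c1cnc(NCc2c(F)ccc3c2CCO3)n2cnnc12` gives the highest of the actual numbers, 67000 nM, and compound 3 `Cc1nccn1-c1cnc(NCc2c(F)ccc3c2CCO3)c2cn[nH]c(=O)c12` gives 7000 nM. Compound 1 `O=C(Nc1ccccc1)c1cnc(NCc2c(F)ccc3c2CCO3)n2cnnc12` gives < 1000 nM, which is a limit and not a number. Compound 4 `O=C1c2ccccc2CN1c1cnc(NCc2c(F)ccc3c2CCO3)n2cnnc12` changes compound 2 on the same aromatic carbon: a group of 10 heavy atoms (8 carbon, 1 nitrogen, 1 oxygen; one five-membered non-aromatic ring with 1 hetero atom, one six-membered aromatic ring of carbon only) in place of a group of 7 heavy atoms (4 carbon, 2 nitrogen, 1 oxygen; one five-membered aromatic ring with 2 hetero atoms), on an aromatic carbon. Among the measured compounds shown here, the one measured step at this place is large: an at least 67-fold higher number from compound 1 to compound 2 (1.82 log units; beyond the scatter), with methyl(1,3-oxazol-2-yl)amino replacing phenylcarbamoyl. The group entering compound 4 also holds a six-membered aromatic ring of carbon only, so much of that step may be reversed. The expected change is a large fall, a 22-fold lower number from compound 2 to compound 4 (1.35 log units; beyond the scatter). Compound 4 is estimated at 3000 nM, with an expected range from 700 nM to 15000 nM.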

Compound 4, solubility: 4000 nM
Beside the measured number, compound 4's estimate is 1.3-fold (0.12 log units) below it; low and high end bracket the measured number.
By their numbers in this assay, from the lowest: compounds 4 and 3 (each within the scatter of the next); then compound 2. At a limit, below all of these: compound 1.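

In this assay, the second group tried in place of methyl(1,3-oxazol-2-yl)amino gives a 17-fold lower number from compound 2 to compound 4 (1.22 log units; beyond the scatter), so both groups here that hold a six-membered aromatic ring of carbon only sit on the low side at this aromatic carbon. These two groups are still not equal: an at least 4.0-fold higher number from compound 1 to compound 4 (0.60 log units; beyond the scatter). The entry for compound 1 is a limit and not a number, so the full size of that step stays unknown: the limit of < 1000 nM in this assay, at which 1 of the 4 values shown sits.

As far as these compounds go, how an amine or a carboxylic acid on this carbon would compare with compound 2 remains open. So does the outcome for a morpholine ring there.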